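A few compounds are considered here, and "the series" means these few. Any claim that something is new, unique, unknown or untested is made for them only; others in the source may bear on it.

Measured so far: compound 1 `Oc1ccc(-c2nc3ccccc3s2)cc1O`, compound 2 `COc1ccc(-c2nc3ccccc3s2)cc1OC`, and compound 3 `Oc1ccc(-c2nc3cc(F)ccc3s2)cc1O`.

In a functional assay on HCC 2998 cells (Homo sapiens) for antiproliferative activity (a higher number here means a weaker inhibitor of growth, a lower number a stronger inhibitor of growth), compound 1 gives 6990 nM, compound 2 gives 42500 nM, and compound 3 gives 1640 nM. Compound 1 and compound 2 share neither hydroxyl nor methoxy pattern exactly, and the difference between the two cores is not broken down here. Compound 3 carries fluoro in place of hydrogen on an aromatic carbon, and this change gave a 4.3-fold lower number from compound 1 to compound 3 (0.63 log units; beyond the scatter) in this assay. Compound 4 `COc1ccc(-c2nc3ccc(F)cc3s2)cc1OC` is not yet measured; it carries fluoro in place of hydrogen on an aromatic carbon, the same change made on the core of compound 2. Because the earlier step was a 4.3-fold lower number from compound 1 to compound 3 (0.63 log units; beyond the scatter), a step of similar size is expected here, estimated as a 3.9-fold lower number from compound 2 to compound 4 (0.59 log units; beyond the scatter), though the core of compound 2 sits much higher, so the outcome is less certain. For compound 4 the expected value in this assay is 11000 nM, between 3500 nM and 35000 nM.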

Compound 4, concentration for 50% growth inhibition: 6210 nM
Beside the measured number, compound 4's estimate is 1.8-fold (0.25 log units) above it; measured number inside the range.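

In this assay, placing fluoro in place of hydrogen on an aromatic carbon gives a 6.8-fold lower number from compound 2 to compound 4 (0.84 log units; beyond the scatter), so the number falls on the core of compound 2 as well. The step carries across these two cores in the same direction and at a similar size: the same change on two cores in this assay, a 4.3-fold lower number (0.63 log units; beyond the scatter) from compound 1 to compound 3 and a 6.8-fold lower number (0.84 log units; beyond the scatter) from compound 2 to compound 4, 1.6-fold (0.21 log units) apart, within the scatter of two such steps. Within the data shown here, this rests on only two cores in one assay, so it does not show that the step would hold on other cores, nor does it explain why fluoro lowers the number.

The compounds shown leave open whether chloro, a nitrile or an amine on the same carbon would lower the number too. They also leave open how the step behaves on a core carrying one hydroxyl and one methoxy group.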